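The compounds below may be only part of what the source reports. "The series", "measured", "known", "first", "only" and "open" are said of these compounds alone.

Measured so far in a functional assay on the whole organism (stomach) for inhibition, with Canis familiaris (Canis lupus familiaris) as the target, at a dose of 8 mg/kg by the oral route; a higher number here means a stronger effect of the compound at the dose given, a lower number a weaker effect:
compound 1, `Cc1nc2c(CCc3ccccc3)cccn2c1N`: 52%
compound 2, `Cc1nc2c(/C=C\c3ccccc3)cccn2c1C`: 74%
compound 3, `Cc1nc2c(/C=C/c3ccccc3)cccn2c1C`: 3%

Compound 2 stands highest of these three in this assay; compound 1 sits lower, and compound 3 lowest. For the measured compounds named here, the only single-point step measured is a number 71 percentage points lower from compound 2 to compound 3 (beyond the scatter), which rests on (the fact that compounds 2 and 3 differ only in the configuration as drawn). Compound 4, `Cc1nc2c(/C=C\c3ccccc3)cccn2c1N`, keeps the geometry of compound 2 and changes one group: amino in place of methyl on an aromatic carbon. Going by the values given here, no measured step follows exactly this change; compound 1 carries the same amino group but also a different linker, so its value gives only a loose hint. Compound 4 is therefore expected to stay near compound 2, with the estimated shift a number 12 percentage points lower from compound 2 to compound 4 (beyond the scatter). The estimate for compound 4 is 62%, between 35% and 85%.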

Compound 4, a percentage reported as inhibition, in the whole organism at one dose (the size of the read-out at that dose, not a potency): 4%
Compound 4: middle estimate off by 58 percentage points, on the high side; measured number outside the range, below it.
By their numbers in this assay, from the lowest: compounds 3 and 4 (each within the scatter of the next); then compound 1; then compound 2.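

In this assay, amino in place of methyl on this aromatic carbon of the five-membered ring gives a number 70 percentage points lower from compound 2 to compound 4 (beyond the scatter), so a swap of one heavy atom at this position can remove most of the effect even with the Z double bond kept. The amino group does not always go with a low number, since compound 1, with a different linker, gives 52%. Nothing at hand explains the size of this step. From the compounds shown here alone, whether a group such as ethyl or hydroxymethyl at this position would keep the effect remains open.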